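A Second Chloro Group on Two Related Cores

A few compounds are considered here, and "the series" means these few. Any claim that something is new, unique, unknown or untested is made for them only; others in the source may bear on it.

Measured compounds:
- compound 1, `ClCc1cccc(Cn2cnc3ncnc(Cl)c32)c1`: "not determined" (no result reported) in a functional assay on HOP-92 cells (Homo sapiens) for cytotoxicity, read by sulforhodamine B assay, with a stated time of 48 h; a higher number here means a weaker inhibitor of growth, a lower number a stronger inhibitor of growth
- compound 2, `ClCc1cccc(Cn2cnc3c(Cl)ncnc32)c1`: 2450 nM
- compound 3, `ClCc1cccc(Cn2cnc3c(Cl)nc(Cl)nc32)c1`: 1820 nM

Compounds 2 and 3 differ by one change, (chloro in place of hydrogen on an aromatic carbon). That change gave a 1.3-fold lower number from compound 2 to compound 3 (0.13 log units; within the scatter), so the two compounds cannot be told apart by this measurement.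

Compound 1 is built from the same atoms as compound 2, joined differently; the difference between the two cores is not broken down here. Compound 4, `ClCc1cccc(Cn2cnc3nc(Cl)nc(Cl)c32)c1`, arises from compound 1 by chloro in place of hydrogen on an aromatic carbon. The place of the entering group is described in the same words as for the change from compound 2 to compound 3, so this is the same change applied to the other core.

Compound 1 has no number, so the expectation for compound 4 rests only on compounds 2 and 3, which both sit near the same concentration, and on the step of a 1.3-fold lower number from compound 2 to compound 3 (0.13 log units; within the scatter), which stayed within the scatter. Compound 4 is therefore expected to give about 2500 nM, estimated between 700 nM and 9000 nM.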

Compound 4, concentration for 50% growth inhibition: 1470 nM
For compound 4 the middle estimate is 1.7-fold (0.23 log units) above the measured one, within the range that was stated.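

In this assay compound 1 gives "not determined" (no result reported), so the step from compound 1 to compound 4 cannot be read. The compounds shown leave open what the added chloro group does on the core of compound 1, and whether that matches the step on the other core. Nothing here accounts for the value of compound 4.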